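The source may report more compounds than this note shows. Statements on the series, on what has been measured and on what is new or still open speak of the compounds shown alone.

Of the compounds shown here, three of a shared core have been measured in an ADME assay on Caco-2 cells (Homo sapiens) for permeability, in the apical to basolateral direction; on this read-out higher numbers stand for higher permeability and lower numbers for lower permeability. Compound 1 `C=C(C)C(=O)N1CCC(CN(C2Cc3cc(C#N)ccc3N(Cc3cncn3C)C2)S(=O)(=O)c2ccccn2)CC1` gives 0.5 10^-6 cm/s, compound 2 `Cn1cncc1CN1CC(N(CC2CCN(C(=O)c3ccco3)CC2)S(=O)(=O)c2ccccn2)Cc2cc(C#N)ccc21` gives 0.5 10^-6 cm/s, and compound 3 `Cn1cnc(S(=O)(=O)N2CCC(CN(C3Cc4cc(C#N)ccc4N(Cc4cncn4C)C3)S(=O)(=O)c3ccccn3)CC2)c1` gives the lowest of the three numbers, 0.1 10^-6 cm/s; the step of a 5.0-fold lower number from compound 1 to compound 3 (0.70 log units; beyond the scatter) and the step of a 5.0-fold lower number from compound 2 to compound 3 (0.70 log units; beyond the scatter) were both modest yet beyond the scatter, while no change at the digits printed from compound 1 to compound 2 (within the scatter). Compound 4 `Cn1cncc1CN1CC(N(CC2CCN(C(=O)CC(C)(C)C)CC2)S(=O)(=O)c2ccccn2)Cc2cc(C#N)ccc21` differs from compound 3 in one place: neopentylcarbonyl in place of (1-methyl-1H-imidazol-4-yl)sulfonyl on an amine nitrogen in a ring. This change reverses the direction of the two measured steps that bear on it, since both replaced an acyl group on the same ring nitrogen with the imidazolyl sulfonyl. Compound 4 is therefore expected to show a 5.0-fold higher number from compound 3 to compound 4 (0.70 log units; beyond the scatter) in this assay, and its estimated permeability is 0.5 10^-6 cm/s, in the range 0.2 10^-6 cm/s to 1.2 10^-6 cm/s.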

Compound 4, apparent permeability: 0.5 10^-6 cm/s
Compound 4: middle estimate and measured number agree at the digits printed; the range from low to high includes it.
By their numbers in this assay, from the lowest: compound 3; then compounds 1, 2 and 4 (each within the scatter of the next).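

In this assay neopentylcarbonyl, which has no ring, matches the two earlier carbonyl groups on this ring nitrogen: the data show no change at the digits printed from compound 2 to compound 4 (within the scatter) and no change at the digits printed from compound 1 to compound 4 (within the scatter) when the group on the carbonyl carbon is exchanged. With a 5.0-fold higher number from compound 3 to compound 4 (0.70 log units; beyond the scatter) as well, the sulfonyl compound now stands apart from three different carbonyl groups at this place. Going by these compounds, whether a methylsulfonyl group here would give the number of compound 3, or a carbonyl group bearing an amine would match the others, stays open. Nothing given here explains these steps.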